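A few compounds are considered here, and "the series" means these few. Any claim that something is new, unique, unknown or untested is made for them only; others in the source may bear on it.

Measured compounds in a functional assay on HUVEC cells (Homo sapiens); on this read-out higher numbers stand for an effect only at larger amounts of compound and lower numbers for an effect already at smaller amounts:
compound 1, `COC1=C(C)C(=O)/C(=C(O)/C=C/c2cccc(OC)c2)C(=O)C1(C)C`, gives < 4 ug/mL, which is a limit of the assay and not a number.
compound 2, `COC1=C(C)C(=O)/C(=C(O)/C=C/c2ccc(C)cc2)C(=O)C1(C)C`, gives < 4 ug/mL, again a limit.
compound 3, `CCc1ccc(/C=C/C(O)=C2/C(=O)C(C)=C(OC)C(C)(C)C2=O)cc1`, gives < 4 ug/mL, again a limit.

Compound 1 therefore stands only at a limit, and the two other values shown are limits as well; all three sit at the limit of < 4 ug/mL in this assay, at which 3 of the 3 values shown sit. The steps a step that the two limits leave unreadable from compound 1 to compound 2, a step that the two limits leave unreadable from compound 1 to compound 3 and a step that the two limits leave unreadable from compound 2 to compound 3 cannot be read, as each end of every step is a limit, so the three measured compounds cannot be told apart on these numbers.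

Compound 4, `C=Cc1ccccc1/C=C/C(O)=C1/C(=O)C(C)=C(OC)C(C)(C)C1=O`, differs from compound 1 in one place: 2-vinylphenyl in place of 3-methoxyphenyl on a double-bonded chain carbon bound to a double-bonded chain carbon. For the measured compounds named here, no measured step bears on this change with a readable size, and the three measured compounds give no hint of any compound falling away from the limit. Compound 4 is therefore expected to sit in the same region, with an estimate of 2.5 ug/mL and a range from 0.8 ug/mL to 8 ug/mL. The expected step that the limit leaves unreadable from compound 1 to compound 4 is accordingly estimated to stay within the scatter.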

Compound 4, concentration for half-maximal effect: < 1.1 ug/mL
Compound 4 gave a limit, no number (the forecaster's own chance of this, stated with the estimate: 65%); at least 2.2-fold (0.35 log units) between middle value and limit.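

For the compounds shown here, no step from compound 1, compound 2 or compound 3 to compound 4 can be read, because all four compounds stand at limits, compound 4 at its own: the limit of < 1.1 ug/mL in this assay, at which 1 of the 4 values shown sits. Still open, on these data alone, is how far the four compounds really differ in this assay, since their true values lie beyond those limits, and whether 2-vinylphenyl differs from the other groups at all.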